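The source may hold more compounds than are shown below. What is called first, only, known or untested is meant among the compounds shown, and "the series" means these compounds.

Measured so far in an assay on U2OS cells for inhibition of secreted frizzled-related protein 1 (Homo sapiens), read by a luciferase reporter, with a stated time of 18 h; on this read-out lower numbers stand for an effect already at smaller amounts and higher numbers for an effect only at larger amounts of compound:
compound 1 `O=C(c1ccccn1)N1CCC(NS(=O)(=O)c2cc(S(=O)(=O)c3ccccc3)ccc2C(F)(F)F)CC1`: 230 nM
compound 2 `O=S(=O)(NC1CCN(S(=O)(=O)c2ccccc2)CC1)c1cc(S(=O)(=O)c2ccccc2)ccc1C(F)(F)F`: 210 nM
compound 3 `O=C(O)c1ccc(S(=O)(=O)N2CCC(NS(=O)(=O)c3cc(S(=O)(=O)c4ccccc4)ccc3C(F)(F)F)CC2)cc1`: 110 nM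

Compound 3 gives the lowest of the three numbers; its step to compound 2 stays within the scatter, so no order between those two is claimed, while a 2.1-fold lower number from compound 1 to compound 3 (0.32 log units; beyond the scatter) lies beyond it. Compound 4 `O=S(=O)(NC1CCN(S(=O)(=O)c2cccc(-c3nnn[nH]3)c2)CC1)c1cc(S(=O)(=O)c2ccccc2)ccc1C(F)(F)F` carries 3-(1H-tetrazol-5-yl)phenyl in place of 4-carboxyphenyl on a sulfonyl sulfur. Among the measured compounds shown here, two measured steps bear on this change at the same sulfonyl sulfur: a 1.9-fold lower number from compound 2 to compound 3 (0.28 log units; within the scatter), within the scatter, and a 2.1-fold lower number from compound 1 to compound 3 (0.32 log units; beyond the scatter), modest. For the measured compounds named here, no measured pair tests a tetrazolyl group, so the expectation rests only on the small size of these steps. Compound 4 is therefore expected at 150 nM, with a range of 50 nM to 450 nM. The expected step is a 1.4-fold higher number from compound 3 to compound 4 (0.13 log units; within the scatter), within the scatter.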

Compound 4, half-maximal effective concentration: 1200 nM
The estimate for compound 4 lay 8.0-fold (0.90 log units) below the measured number; measured number above the stated range.
By their numbers in this assay, from the lowest: compounds 3, 2 and 1 (each within the scatter of the next, the first and the last beyond it); then compound 4.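

In this assay the aryl group on this sulfonyl sulfur turns out not to be freely changeable: 3-(1H-tetrazol-5-yl)phenyl in place of 4-carboxyphenyl gives an 11-fold higher number from compound 3 to compound 4 (1.04 log units; beyond the scatter) as a large step. Likewise, 1H-tetrazol-5-yl in place of hydrogen on an aromatic carbon gives a 5.7-fold higher number from compound 2 to compound 4 (0.76 log units; beyond the scatter) as a modest step, whereas carboxy in place of hydrogen stayed within the scatter. No evidence at hand explains this result.

The compounds shown change the group and its ring position together, so the two remain unseparated. A 3-carboxyphenyl or 4-(1H-tetrazol-5-yl)phenyl group on this sulfur would separate them.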